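Bromo to methoxy on the indole series: toxicity outlook

The source may hold more compounds than are shown below. What is called first, only, known or untested is meant among the compounds shown, and "the series" means these compounds.

Three compounds of a shared core are in view. Compound 1 `COc1ccc2[nH]cc(C(=O)/C(C#N)=C/C=C(\Cl)c3ccc(OC)c(OC)c3)c2c1` carries a methoxy on the fused bicyclic part and a dimethoxyphenyl on the chain; in an ADME assay on Vero cells (Chlorocebus sabaeus) for cytotoxicity, read by sulforhodamine B assay, with a stated time of 48 h (on this read-out higher numbers stand for lower toxicity in this test and lower numbers for higher toxicity in this test), compound 1 gives "not determined" (no result reported), so no result is reported for it. Within the data shown here, compound 2 `COc1cc(/C(Cl)=C/C=C(\C#N)C(=O)c2c[nH]c3ccc(Br)cc23)cc(OC)c1OC` carries a bromo on the fused bicyclic part and a trimethoxyphenyl on the chain; in this assay compound 2 gives 41500 nM, the only number available so far, so nothing can yet be said about where it stands against the others.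

Compound 3 `COc1ccc2[nH]cc(C(=O)/C(C#N)=C/C=C(\Cl)c3cc(OC)c(OC)c(OC)c3)c2c1` is the next entry. The change from compound 2 to compound 3 is methoxy in place of bromo on an aromatic carbon, and the trimethoxyphenyl on the chain is kept. Among the measured compounds shown here, no step between two measured compounds is available for this change, so there is no reference for its size. The expected step is a 1.3-fold higher number from compound 2 to compound 3 (0.12 log units; within the scatter), a shift toward lower toxicity that stays close to the scatter. For compound 3 the estimate in this assay is 55000 nM, with a range from 22000 nM to 130000 nM.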

Compound 3, concentration lethal to 50% of the cells: 45200 nM
The estimate for compound 3 lay 1.2-fold (0.09 log units) above the measured number; the range from low to high includes it.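

In this assay, methoxy in place of bromo on an aromatic carbon, meta to a fused ring and para to a fused ring, gives a 1.1-fold higher number from compound 2 to compound 3 (0.04 log units; within the scatter), so the two groups cannot be told apart at this position on this read-out. Among these compounds, this is the first readable step, and it holds only with the trimethoxyphenyl on the chain kept; a single pair sets no pattern for other chain groups. No measured property of either group is available to interpret this result.

From the compounds shown here alone, the step from compound 1 to compound 3, dimethoxyphenyl to trimethoxyphenyl on the chain, cannot be read, since compound 1 has no reported result, and the part played by that aryl group stays open. Also open, going by these compounds, is whether a group of another kind on the same aromatic carbon, such as an amine or a carboxylic acid, would give a step beyond the scatter, or would stay as close to compound 2 as methoxy does.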